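This account rests on a few compounds, and the source may have more. Where it says the series, first, only, none or still open, it means among the compounds named here.

Measured in an ADME assay on microsomes from liver (Homo sapiens) for metabolic stability, using NADPH, with a stated time of 30 min; a lower number here means that less of the compound is left, a higher number that more of the compound is left
compound 1 `Cc1nc(C)c(-c2csc(Nc3ccc(C(=O)N4C5CNCC4COC5)cn3)n2)s1` gives 57.9%
compound 2 `COC(=O)N1CC2CCCC(C1)N2C(=O)c1ccc(Nc2nc(-c3sc(C)nc3C)cs2)nc1` gives 33.7%

Compound 1 at 57.9% stands as the higher of the two readings in this assay, and its gap to compound 2 lies beyond the usual scatter. Within the data shown here, with only two readings, no wider ranking can be drawn.

The next entry is compound 3 `COC(=O)N1CCN(C(=O)c2ccc(Nc3nc(-c4sc(C)nc4C)cs3)nc2)CC1`, which keeps the core of compound 1 and changes only the amine part of the amide. The change is a group of 10 heavy atoms (6 carbon, 2 nitrogen, 2 oxygen; one six-membered non-aromatic ring with 2 hetero atoms) in place of a group of 9 heavy atoms (6 carbon, 2 nitrogen, 1 oxygen; 2 six-membered non-aromatic rings with 2 hetero atoms each), on a carbonyl carbon and places a 4-(methoxycarbonyl)piperazin-1-yl group on the carbonyl carbon. The new group has one six-membered non-aromatic ring with 2 hetero atoms in place of two such rings.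

Among the measured compounds shown here, no measured step covers this change, so the expectation rests on the two readings alone and stays loose. Compound 1 marks the upper reading, and compound 2 at 33.7% is the only lower reference, so a fall is expected rather than a rise. The expected change is estimated as a number 15.9 percentage points lower from compound 1 to compound 3 (beyond the scatter) and may only just clear the scatter.

For compound 3 the estimate is 42% with an expected range from 22% to 62% in this assay as the working figure.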

Compound 3, percent of the compound remaining: 94.1%
Estimate against measurement, compound 3: 52.1 percentage points below; the whole stated range lies below it.
By their numbers in this assay, from the lowest: compound 2; then compound 1; then compound 3.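

In this assay, the amine part of the amide, on a carbonyl carbon whose other neighbours are aromatic carbon, proves to be a strong handle on the amount of compound left, with a large step of a number 36.2 percentage points higher from compound 1 to compound 3 (beyond the scatter) on the shared core. The step also shows that a 4-(methoxycarbonyl)piperazin-1-yl group, with one six-membered non-aromatic ring in place of two and no hydrogen-bond donor in place of one, is compatible with a high reading, as compound 3 gives 94.1%. This single step changes ring count, donor count and the double bond outside aromatic rings together, so it does not separate their contributions, and nothing available bears on the reason for the rise.

Still open, going by these compounds, is whether the high reading stays with an acetyl or a methanesulfonyl group in place of the methoxycarbonyl on the piperazine, or with a morpholine ring on the carbonyl carbon. Also open, on these data alone, is whether the unsubstituted piperazine reads closer to compound 1 or to compound 3.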